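Ethyl to 4-methylphenyl on an aromatic nitrogen

The compounds below may be only part of what the source reports. "The series", "measured", "known", "first", "only" and "open" are said of these compounds alone.

In a functional assay on HT-29 cells (Homo sapiens) for antiproliferative activity, read by MTT assay, with a stated time of 72 h (on this read-out lower numbers stand for stronger inhibition and higher numbers for weaker inhibition), compound 1 (`CCn1ccnc1-c1cc(OC)c(OC)c(OC)c1`) gives > 100000 nM as a limit of the assay and not a number. Compound 3 (`COc1cc(-c2nccn2-c2ccc(C)cc2)cc(OC)c1OC`) carries 4-methylphenyl in place of ethyl on an aromatic nitrogen. Among the compounds with values here, no measured pair isolates this change. The expectation rests on compound 2 (`COc1ccc(-n2ccnc2-c2cc(OC)c(OC)c(OC)c2)cc1[N+](=O)[O-]`) at 600 nM with a substituted phenyl on that nitrogen. A large step towards stronger inhibition is expected in this assay with an at least 50-fold lower number from compound 1 to compound 3 (1.69 log units; beyond the scatter) as its estimated size. For compound 3 the estimate is 2000 nM with an expected range of 200 nM to 30000 nM on this read-out.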

Compound 3, half-maximal inhibitory concentration: 1600 nM
For compound 3 the middle estimate is 1.3-fold (0.10 log units) above the measured one, and the stated range covers the measured number.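

In this assay, the aromatic nitrogen now has a direct one-place comparison: 4-methylphenyl in place of ethyl gives an at least 62-fold lower number from compound 1 to compound 3 (1.79 log units; beyond the scatter). Compound 1 gives > 100000 nM, which is a limit of the assay and not a number. The step therefore reads as a minimum size, not an exact one: the limit of > 100000 nM in this assay, at which 1 of the 3 values shown sits.

The compounds shown leave open whether the step needs an aromatic ring on this nitrogen or only more carbon; a cyclohexyl group or a longer chain there would separate the two.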